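This account rests on a few compounds, and the source may have more. Where it says the series, first, only, none or still open, it means among the compounds named here.

Compound 1 `CN(C)c1ccc(NCc2cncn2Cc2ccc(-c3ccccc3)cc2)cc1-c1ccccc1` is the anchor of the series. In a toxicity assay on NIH3T3 cells (Mus musculus) for cytotoxicity, read by resazurin assay (a lower number here means that less compound is needed, a higher number that more compound is needed for the effect), compound 1 gives only a limit of the assay, > 1000 nM, and no number. Compound 2 `COC(=O)c1ccc(NCc2cncn2Cc2ccccc2-c2ccccc2)cc1-c1ccccc1` carries the same core with another arrangement of the outer groups; in this assay compound 2 gives "not determined" (no result reported). Among the measured compounds shown here, the one piece of evidence is the limit of > 1000 nM in this assay, at which 1 of the 2 values shown sits. Compound 3 `CCOC(=O)c1ccc(NCc2cncn2Cc2ccc(-c3ccccc3)cc2)cc1-c1ccccc1` differs from compound 1 in one place: ethoxycarbonyl in place of dimethylamino on an aromatic carbon. For the measured compounds named here, no measured step exists, so the expected step from compound 1 to compound 3 in this assay is a step that the limit leaves unreadable from compound 1 to compound 3, none beyond the scatter. Compound 3 is therefore estimated at 3000 nM, between 1000 nM and 10000 nM, most likely reported again only as a limit.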

Compound 3, half-maximal effective concentration: > 10000 nM
Compound 3 gave a limit, no number (the forecaster's own chance of this, stated with the estimate: 70%); middle value at least 3.3-fold (0.52 log units) away from the limit.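

Compound 1 and compound 3 both give only limits in this assay, so the step between them cannot be read. From the compounds shown here alone, whether ethoxycarbonyl in place of dimethylamino shifts the value at all, and how far, stays open.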